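This account rests on a few compounds, and the source may have more. Where it says the series, first, only, none or still open, it means among the compounds named here.

Compounds measured so far:
- compound 1, `CCCN(CCC(F)(F)F)Cc1c(C(F)(F)F)nc2n(-c3c(C)cc(C)cc3C)c(Cl)cn12`: 12 nM
- compound 2, `CCCCN(CC)Cc1c(C(F)(F)F)nc2n(-c3c(C)cc(C)cc3C)c(Cl)cn12`: 78 nM
- compound 3, `CCCN(Cc1c(C(F)(F)F)nc2n(-c3c(C)cc(C)cc3C)c(Cl)cn12)CC1CCC1`: 5.3 nM

All three share one core and differ only in the amine carried on the saturated chain carbon bound to an aromatic carbon. In an assay on cells for displacement of a labelled ligand from corticotropin-releasing factor receptor 1 (Homo sapiens), with a stated time of 100 min (a lower number here means a stronger inhibitor, a higher number a weaker inhibitor), compound 1 gives 12 nM, which puts it second highest of the three numbers; compound 3 sits closest to it, compound 2 furthest away.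

Compound 4, `CCN(CCC1CC1)Cc1c(C(F)(F)F)nc2n(-c3c(C)cc(C)cc3C)c(Cl)cn12`, has not yet been measured. Against compound 1 the change is (2-cyclopropylethyl)(ethyl)amino in place of propyl(3,3,3-trifluoropropyl)amino on a saturated chain carbon bound to an aromatic carbon.

For the measured compounds named here, two measured steps bear on this. Swapping the whole amine for butyl(ethyl)amino gave a 6.5-fold higher number from compound 1 to compound 2 (0.81 log units; beyond the scatter), so an ethyl on the nitrogen paired with a plain chain went with a weaker inhibitor. Putting a cyclobutyl in place of the 2,2,2-trifluoroethyl gave a 2.3-fold lower number from compound 1 to compound 3 (0.35 log units; beyond the scatter), so a small carbon ring in place of the fluorines went with a somewhat stronger one. Compound 4 combines both kinds of change, an ethyl and a cyclopropyl-bearing chain, and the two pulls point in opposite directions.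

The expected outcome is therefore a step of a 1.7-fold higher number from compound 1 to compound 4 (0.22 log units; within the scatter) in this assay, a modest weakening, with wide uncertainty. Compound 4 is estimated at 20 nM, within a range of 7 nM to 60 nM.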

Compound 4, inhibition constant: 13 nM
For compound 4 the middle estimate is 1.5-fold (0.19 log units) above the measured one; measured number inside the range.
By their numbers in this assay, from the lowest: compound 3; then compounds 1 and 4 (each within the scatter of the next); then compound 2.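

In this assay there is a 1.1-fold higher number from compound 1 to compound 4 (0.03 log units; within the scatter), so at this position on a saturated chain carbon bound to an aromatic carbon, an amine with no fluorine can match propyl(3,3,3-trifluoropropyl)amino. The sharper contrast is a 6.0-fold lower number from compound 2 to compound 4 (0.78 log units; beyond the scatter), where cyclopropyl replaces ethyl at the far end of the chain; both compounds keep an ethyl on the amine nitrogen, so that ethyl does not by itself go with the weaker number seen for compound 2. The (cyclobutylmethyl)(propyl)amino group still stands apart, with a 2.5-fold higher number from compound 3 to compound 4 (0.39 log units; beyond the scatter), but both arms of the amine differ in that step, so it cannot be pinned on either arm, and no measurement given here explains any of these steps.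

Still open, from the compounds shown here alone, is how far the ring at the chain end can change, for instance whether a cyclopentyl or a phenyl there would fit the same trend. Also open, going by these compounds, is how the number responds when an oxygen enters the amine, as in a morpholine or a chain ending in a hydroxyl group.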